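A few compounds are considered here, and "the series" means these few. Any claim that something is new, unique, unknown or untested is made for them only; others in the source may bear on it.

Three compounds built on one shared core, each carrying an amide whose nitrogen bears a substituted phenyl ring, have been tested in an assay on isolated protein for inhibition of histone deacetylase 4 (Homo sapiens), with a stated time of 1 h; a lower number here means a stronger inhibitor, a higher number a weaker inhibitor. Compound 1 `O=C(COc1ccc2cc(/C=C3/SC(=O)NC3=O)ccc2c1)Nc1cccc(Cl)c1` gives 3800 nM, compound 2 `O=C(COc1ccc2cc(/C=C3/SC(=O)NC3=O)ccc2c1)Nc1cc(Cl)cc(C(F)(F)F)c1` gives 4000 nM, and compound 3 `O=C(COc1ccc2cc(/C=C3/SC(=O)NC3=O)ccc2c1)Nc1ccc(Br)c(Br)c1` gives 4900 nM. Compound 3 holds the highest of the three numbers, yet every gap among the three stays within the scatter, so the three values cannot be told apart.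

Compound 4 `O=C(COc1ccc2cc(/C=C3/SC(=O)NC3=O)ccc2c1)Nc1ccc(Cl)c(Cl)c1` has not yet been measured. It differs from compound 3 in one place: 3,4-dichlorophenyl in place of 3,4-dibromophenyl on an amide-type nitrogen. The measured steps that bear on this change all reshuffled the halogens on the phenyl attached to the amide nitrogen: a 1.3-fold higher number from compound 1 to compound 3 (0.11 log units; within the scatter), a 1.2-fold higher number from compound 2 to compound 3 (0.09 log units; within the scatter) and a 1.1-fold higher number from compound 1 to compound 2 (0.02 log units; within the scatter). None of them moved the number beyond the scatter. Exchanging one pair of halogens for another on that ring is therefore expected to leave this assay essentially unchanged, and the step expected from this change, a 1.1-fold lower number from compound 3 to compound 4 (0.04 log units; within the scatter), is none beyond the scatter. Compound 4 is thus estimated at 4500 nM, within a range of 2000 nM to 10000 nM.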

Compound 4, half-maximal inhibitory concentration: 5500 nM
Compound 4: the middle estimate sits 1.2-fold (0.09 log units) below what was measured, and the stated range covers the measured number.
By their numbers in this assay, from the lowest: compounds 1, 2, 3 and 4 (each within the scatter of the next).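

The swap of 3,4-dibromophenyl for 3,4-dichlorophenyl on the amide-type nitrogen gives a 1.1-fold higher number from compound 3 to compound 4 (0.05 log units; within the scatter) in this assay, so these two halogen pairs cannot be told apart at this position. The new compound also extends the comparison to an added halogen: adding a chloro to the aromatic ring gives a 1.4-fold higher number from compound 1 to compound 4 (0.16 log units; within the scatter), and replacing 3-chloro-5-(trifluoromethyl)phenyl with 3,4-dichlorophenyl gives a 1.4-fold higher number from compound 2 to compound 4 (0.14 log units; within the scatter), so all four halogen-bearing rings remain indistinguishable in this test. Nothing available explains why these changes leave the number within the scatter.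

As far as these compounds go, all four rings carry only halogens, sometimes with a trifluoromethyl, so it remains open whether an amine, a carboxylic acid or a methoxy group on this ring would shift the number. From the compounds shown here alone, the effect of replacing the phenyl ring with a longer alkyl chain also remains open.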